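The source may report more compounds than this note shows. Statements on the series, on what has been measured and on what is new or still open speak of the compounds shown alone.

Compound 1 `O=C(Nc1cc(C(F)(F)F)cc(C(F)(F)F)c1)c1cc(F)ccc1O` and compound 2 `O=C(Nc1cc(C(F)(F)F)cc(C(F)(F)F)c1)c1cc(Br)ccc1O` share one core and differ only in the halogen on the phenol ring. In a functional assay on KG-1 cells (Homo sapiens) for cytotoxicity, read by luminescence and CellTiter-Glo, with a stated time of 3 days (a lower number here means a stronger inhibitor, a higher number a weaker inhibitor), compound 1 gives 470 nM, while compound 2 gives 300 nM. The change bromo in place of fluoro on an aromatic carbon thus made a step of a 1.6-fold lower number from compound 1 to compound 2 (0.19 log units; within the scatter), a step that lies within the usual scatter of the measurement.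

Compound 3 `N#Cc1ccc(NC(=O)c2ccc(F)cc2O)cc1` rests on a different core, carrying a nitrile on the aniline ring in place of the two trifluoromethyl groups; the difference between the two cores is not broken down here. In this assay compound 3 gives 3150 nM, the highest of the three numbers, and its gaps to compound 1 and to compound 2 both lie beyond the scatter.

Compound 4 `N#Cc1ccc(NC(=O)c2ccc(Br)cc2O)cc1` stands to compound 3 as compound 2 stands to compound 1: the change bromo in place of fluoro on an aromatic carbon is the same kind of change. It is not the same change, since the bromo in compound 2 sits meta to a large group and para to a hydroxy group, whereas in compound 4 it sits meta to a hydroxy group and para to a large group. Because the earlier step of a 1.6-fold lower number from compound 1 to compound 2 (0.19 log units; within the scatter) stayed within the scatter, the step from compound 3 to compound 4 in this assay is expected to be of similar size, a 1.6-fold lower number from compound 3 to compound 4 (0.20 log units; within the scatter). Within the data shown here, compound 4 is therefore estimated at 2000 nM, with a likely range from 1000 nM to 4000 nM, an estimate that rests only on compound 3 at 3150 nM and on the single earlier step.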

Compound 4, half-maximal inhibitory concentration: 1450 nM
For compound 4 the middle estimate is 1.4-fold (0.14 log units) above the measured one; the measured number falls inside the stated range.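

In this assay, bromo in place of fluoro on an aromatic carbon gives a modest step on the second core, a 2.2-fold lower number from compound 3 to compound 4 (0.34 log units; beyond the scatter). Set beside the step on the core of compound 1, this shows that the change carried from one core to the other with no difference that can be told from the scatter: the same change on two cores in this assay, a 1.6-fold lower number (0.19 log units; within the scatter) from compound 1 to compound 2 and a 2.2-fold lower number (0.34 log units; beyond the scatter) from compound 3 to compound 4, 1.4-fold (0.14 log units) apart, within the scatter of two such steps. Among these compounds, it does not show that the change has a reliable effect of its own, since only the step on the second core lies beyond the scatter, and two cores cannot show how the change would behave on a further core, nor why the numbers move as they do.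

The compounds shown leave open what other groups at the same place would do, for example chloro, methyl, an amine or a carboxylic acid, since fluoro and bromo are the only two compared there. They also leave open whether the step would hold if the hydroxy group gave way to a methoxy group, or if the aniline ring carried a group other than nitrile or trifluoromethyl, such as a sulfonamide.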